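This account rests on a few compounds, and the source may have more. Where it says the series, first, only, none or still open, it means among the compounds named here.

In a functional assay for inhibition, with Rattus norvegicus as the target; on this read-out lower numbers stand for stronger inhibition and higher numbers for weaker inhibition:
compound 1 `CC(C)(C)CN/C(=C\[N+](=O)[O-])Nc1ccncc1` gives 10000 nM
compound 2 `CC(N/C(=C\[N+](=O)[O-])Nc1ccncc1)C(C)(C)C` gives 1000 nM
compound 3 `CC(/N=C(/NC#N)Nc1cccnc1)C(C)(C)C` gives 15.9 nM

Compound 1 has the highest number of these three. Compound 4 `CC(C)(C)CN/C(=C\[N+](=O)[O-])Nc1cccnc1` keeps the core of compound 1 but carries pyridin-3-yl in place of pyridin-4-yl on an amine nitrogen. Within the data shown here, the only measured single change (a 10-fold lower number from compound 1 to compound 2 (1.00 log units; beyond the scatter)) lies on the saturated chain, so it says nothing direct about this swap. On these data alone, compound 3 also carries pyridin-3-yl and shows a much lower number (15.9 nM), but it differs from compound 1 in other places too, so the share of the swap is unknown. A modest step to a lower number is therefore expected, with low confidence (a 3.3-fold lower number from compound 1 to compound 4 (0.52 log units; beyond the scatter)). Compound 4 is estimated at 3000 nM (range 400 nM to 15000 nM).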

Compound 4, half-maximal inhibitory concentration: 1000 nM
For compound 4 the middle estimate is 3.0-fold (0.48 log units) above the measured one; the measured number falls inside the stated range.
By their numbers in this assay, from the lowest: compound 3; then compounds 2 and 4 (each within the scatter of the next); then compound 1.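

On an amine nitrogen, pyridin-3-yl in place of pyridin-4-yl gives a 10-fold lower number from compound 1 to compound 4 (1.00 log units; beyond the scatter) in this assay. The two groups have the same atoms, so the attachment of the ring alone changes the number, and this place responds to the change as clearly as the saturated chain did. Nothing measured here explains the change.

On these data alone, whether the swap would give a similar step on the chain of compound 2 remains open. So does how a pyridin-2-yl or a plain phenyl ring would compare at this place.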